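The source may report more compounds than this note shows. Statements on the series, on what has been measured and on what is new or still open speak of the compounds shown alone.

Compound 1, with the structure `Cc1ccc(NC(=O)c2ccc3cccc(O)c3n2)cc1`, was measured in a physicochemical assay for lipophilicity, read by HPLC (a higher number here means a more lipophilic compound, a lower number a more polar compound), where compound 1 gives 2.5. Its closest measured neighbour is compound 2, `O=C(Nc1cccc(Cl)c1)c1ccc2cccc(O)c2n1`, which in this assay gives 2.5. The step of no change at the digits printed from compound 1 to compound 2 (within the scatter), which puts a 3-chlorophenyl in place of a 4-methylphenyl on the amide-type nitrogen, leaves the value unchanged within the scatter, so compound 1 stands level with compound 2 on the numbers available.

Compound 3, `O=C(Nc1ccc([N+](=O)[O-])cc1)c1ccc2cccc(O)c2n1`, has not yet been measured. It differs from compound 1 by nitro in place of methyl on an aromatic carbon, a nitro in place of a methyl on an aromatic carbon. Within the data shown here, only one measured step exists here, the one from compound 1 to compound 2, and it exchanges one group for a different group on the same nitrogen rather than a methyl for a nitro, so it offers no direct guide to the size of this change; it shows only that one change on this part of the molecule left this assay unmoved. A modest decrease is nevertheless expected for compound 3, with the step of a number 0.50 log units lower from compound 1 to compound 3 (beyond the scatter) estimated in that direction. Compound 3 is therefore estimated at 2, within a range from 1.5 to 2.5.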

Compound 3, partition coefficient: 2.5
Estimate against measurement, compound 3: 0.50 log units below; low and high end bracket the measured number.
By their numbers in this assay, from the lowest: compounds 1, 2 and 3 (each within the scatter of the next).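

In this assay, putting nitro in place of methyl on this aromatic carbon, para to a large group, gives no change at the digits printed from compound 1 to compound 3 (within the scatter). The earlier step exchanged one substituted phenyl group for another, whereas this one keeps the ring and swaps a single carbon for a group of three heavy atoms with two hydrogen-bond acceptors, and even a change of that kind leaves the reading where it was, so across the three compounds shown, the changes made on this ring have not moved the number beyond the scatter. No separate measurement is available to explain this result.

The compounds shown leave open whether an amine, a carboxylic acid or a longer alkyl chain on the same aromatic carbon would also leave this assay unmoved, since each of these differs from methyl and nitro in its atoms and shape. All three compounds also share the same core, so how far a change made within that core would shift this assay remains an open question.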